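Bromo gives way to chloro on compound 3

The compounds below may be only part of what the source reports. "The series", "measured", "known", "first", "only" and "open" are said of these compounds alone.

In an ADME assay on L1210/0 cells (Mus musculus) for cytotoxicity, with a stated time of 48 h (on this read-out lower numbers stand for stronger inhibition and higher numbers for weaker inhibition), compound 3 `O=C1O/C(=C\Cn2cc(Br)c(=O)[nH]c2=O)C(OCc2ccccc2)=C1OCc1ccccc1` gives 7500 nM. This is the middle of three numbers: compound 1 `COc1ccc(-c2ncnc3c2ncn3C[C@@H]2C[C@H](CO)c3ccccc32)cc1` reads higher at 17600 nM, and compound 2 `O=C1O/C(=C\Cn2cc(C(F)(F)F)c(=O)[nH]c2=O)C(OCc2ccccc2)=C1OCc1ccccc1` reads lower at 2000 nM. Compound 4 `O=C1O/C(=C\Cn2cc(Cl)c(=O)[nH]c2=O)C(OCc2ccccc2)=C1OCc1ccccc1` is not yet measured. Its difference from compound 3 is chloro in place of bromo on an aromatic carbon, which means chloro in place of bromo on an aromatic carbon. Within the data shown here, only one measured step bears on this change: a 3.8-fold higher number from compound 2 to compound 3 (0.57 log units; beyond the scatter), a modest step with bromo in place of trifluoromethyl. Among the measured compounds shown here, no measured compound shows how chloro itself behaves, so no step beyond the scatter is expected in this assay. The expected step is a 1.3-fold lower number from compound 3 to compound 4 (0.10 log units; within the scatter). For compound 4, the estimate is 6000 nM, within a range of 2500 nM to 14000 nM.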

Compound 4, half-maximal inhibitory concentration: 12200 nM
Compound 4: the middle estimate sits 2.0-fold (0.31 log units) below what was measured, within the range that was stated.
By their numbers in this assay, from the lowest: compound 2; then compounds 3, 4 and 1 (each within the scatter of the next, the first and the last beyond it).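

In this assay, chloro in place of bromo on this aromatic carbon gives a 1.6-fold higher number from compound 3 to compound 4 (0.21 log units; within the scatter), so the assay does not separate these two halogens here. Chloro in place of trifluoromethyl gives a 6.1-fold higher number from compound 2 to compound 4 (0.79 log units; beyond the scatter), which leaves trifluoromethyl as the one group of the three that stands clearly apart, with the lowest number. Nothing available explains that difference. Still open, going by these compounds, is how a nitrile, a methyl group or an amine on this same carbon would read. Whether trifluoromethyl keeps its lower number on a different core is also unknown.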